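Swapping the ethoxy tail of compound 3 for propyl

The compounds below may be only part of what the source reports. "The series", "measured", "known", "first", "only" and "open" are said of these compounds alone.

Compound 3 `CCOCc1cn(-c2ccc(NC(=O)Nc3cccc(F)c3)cc2)nn1` gives the highest number of the three measured compounds in an assay for inhibition of ATP-dependent RNA helicase DDX3X (Homo sapiens), read by FRET, with a stated time of 40 min, in the presence of a further agent that is not named here (a lower number here means a stronger inhibitor, a higher number a weaker inhibitor), at 21200 nM; the nearest is compound 2 `CC(C)CCc1cn(-c2ccc(NC(=O)Nc3cccc(F)c3)cc2)nn1` at 200 nM, and compound 1 `CC(C)CCc1cn(-c2ccc(NC(=O)Nc3ccccc3F)cc2)nn1` sits at 120 nM. Compound 4 `CCCCc1cn(-c2ccc(NC(=O)Nc3cccc(F)c3)cc2)nn1` differs from compound 3 by propyl in place of ethoxy on a saturated chain carbon bound to an aromatic carbon. The step that bears on this is a 110-fold higher number from compound 2 to compound 3 (2.03 log units; beyond the scatter), where an isobutyl chain was replaced by the ethoxy group that compound 4 now loses again for a plain carbon chain. The other step, a 1.7-fold higher number from compound 1 to compound 2 (0.22 log units; within the scatter), concerns the fluorophenyl group and lies within the scatter, so it says little here. A large drop in the number is therefore expected for compound 4, roughly the reverse of that step, a 53-fold lower number from compound 3 to compound 4 (1.72 log units; beyond the scatter). For compound 4 the expected value in this assay is 400 nM, with a range from 150 nM to 2000 nM.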

Compound 4, half-maximal inhibitory concentration: 600 nM
Beside the measured number, compound 4's estimate is 1.5-fold (0.18 log units) below it; the measured number falls inside the stated range.
By their numbers in this assay, from the lowest: compounds 1 and 2 (each within the scatter of the next); then compound 4; then compound 3.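

In this assay, replacing ethoxy with propyl exchanges one oxygen for a carbon and leaves the heavy-atom count unchanged, yet it gives a 35-fold lower number from compound 3 to compound 4 (1.55 log units; beyond the scatter). Removing a methyl from the isobutyl-bearing chain matters far less, with a 3.0-fold higher number from compound 2 to compound 4 (0.48 log units; beyond the scatter), though that modest step still lies beyond the scatter. Among these compounds, this position therefore accepts a plain carbon chain much better than the ethoxy-containing chain. No measured evidence here explains the gap. From the compounds shown here alone, it remains open whether an amine in the chain, or a longer carbon chain, would follow compound 3 or compound 4.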